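A Hydroxy Added to Compound 2

This account rests on a few compounds, and the source may have more. Where it says the series, first, only, none or still open, it means among the compounds named here.

The study compares three measured compounds and one unmeasured analogue in a functional assay on cells (Melanoma cell) for cytotoxicity against Melanoma cell line (Homo sapiens), read by sulforhodamine B assay, with a stated time of 48 h; on this read-out lower numbers stand for stronger inhibition of growth and higher numbers for weaker inhibition of growth. Compound 1 `COc1ccc2c(c1)/C(=C/c1c(-c3ccncc3)nc3sccn13)C(=O)N2C` gives 5970 nM in this assay. Compound 3 `O=C1Nc2ccccc2C1=Cc1c(-c2ccncc2)nc2sccn12` gives 3270 nM. Compound 2 `COc1nc2sc(C)cn2c1/C=C1/C(=O)Nc2ccccc21` gives 16200 nM, the highest of the three numbers: compound 1 stands nearest to it, and compound 3 furthest, both gaps lying beyond the scatter, so compound 2 shows the weakest inhibition of growth among these three.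

The unmeasured compound 4 `COc1nc2sc(C)cn2c1/C=C1/C(=O)Nc2ccc(O)cc21` differs from compound 2 in one place: hydroxy in place of hydrogen on an aromatic carbon. Going by the values given here, no step between measured compounds with this change is available, so what follows rests on the shared core of compound 2 and the single change.

The step that the account expects is a 1.6-fold lower number from compound 2 to compound 4 (0.21 log units; within the scatter), a change of modest size, most probably towards a lower number, though with enough uncertainty that no change beyond the scatter would also fit. Compound 4 is therefore expected to give 10000 nM in this assay, within a range from 4000 nM to 30000 nM.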

Compound 4, concentration for 50% growth inhibition: 4880 nM
For compound 4 the middle estimate is 2.0-fold (0.31 log units) above the measured one; the range from low to high includes it.
By their numbers in this assay, from the lowest: compounds 3, 4 and 1 (each within the scatter of the next); then compound 2.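

In this assay, going by these compounds alone, the hydroxy in place of hydrogen gives a 3.3-fold lower number from compound 2 to compound 4 (0.52 log units; beyond the scatter), and this is the first step between measured compounds in this set, since the earlier values could only be set side by side across several differences at once. It shows that this aromatic carbon, on the six-membered aromatic ring of carbon only, meta to a fused ring and para to a fused ring, is not indifferent to substitution: adding one oxygen there, with its hydrogen-bond donor and acceptor, moves the growth-inhibition number beyond the scatter and towards stronger inhibition of growth. No measurement available here accounts for this gain, so the step stands as an observation and nothing more.

The compounds shown leave open whether other groups at this same carbon, such as an amine, a chlorine atom or a carboxylic acid, would move the number as far, in the same direction or not at all. They also leave open whether the hydroxy would bring a similar step on the core of compound 3, or at the other free carbons of the same ring.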